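Moving the aryl group one carbon outward in the side chain

A few compounds are considered here, and "the series" means these few. Any claim that something is new, unique, unknown or untested is made for them only; others in the source may bear on it.

Compound 2 `Cc1cccc(Cc2cnc(CCc3ccc(-c4ccccc4C(=O)O)cc3)[nH]2)c1` stands highest of the two numbers recorded in an in vitro functional assay on cells for agonist activity at Bombesin receptor subtype-3 (Mus musculus), read by luminescence and calcium flux (on this read-out higher numbers stand for an effect only at larger amounts of compound and lower numbers for an effect already at smaller amounts), where compound 2 gives 75 nM. Among the measured compounds shown here, the nearest comparison is compound 1 `O=C(O)c1ccccc1-c1ccc(CCc2ncc(CC3CCC3)[nH]2)cc1`, which in this assay gives 7.1 nM; the step between them, an 11-fold higher number from compound 1 to compound 2 (1.02 log units; beyond the scatter), is the only measured step in the set. The next compound, compound 3 `O=C(O)c1ccccc1-c1ccc(CCc2ncc(CCc3ccccc3)[nH]2)cc1`, differs from compound 2 by benzyl in place of 3-methylphenyl on a saturated chain carbon bound to an aromatic carbon. For the measured compounds named here, the one measured step touches the same position, exchanging cyclobutyl for 3-methylphenyl, and it was large. Compound 3 carries a ring on a longer tether, as compound 1 does, and has the same atoms as compound 2 joined differently; the expectation for compound 3 is therefore a number below that of compound 2 but not as low as that of compound 1, an estimated step of a 2.5-fold lower number from compound 2 to compound 3 (0.40 log units; beyond the scatter). The estimate for compound 3 in this assay is 30 nM, within a range of 8 nM to 120 nM.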

Compound 3, half-maximal effective concentration: 174 nM
Compound 3: the middle estimate sits 5.8-fold (0.76 log units) below what was measured; measured number outside the range, above it.
By their numbers in this assay, from the lowest: compound 1; then compound 2; then compound 3.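

In this assay, the same atoms rearranged from 3-methylbenzyl to phenethyl give a 2.3-fold higher number from compound 2 to compound 3 (0.37 log units; beyond the scatter), so the arrangement of the side chain alone shifts the number beyond the scatter, and the added length of the tether does not bring the aromatic ring closer to the cyclobutyl result. Against the cyclobutyl side chain, benzyl in place of cyclobutyl gives a 25-fold higher number from compound 1 to compound 3 (1.39 log units; beyond the scatter), so among the three compounds, both side chains with an aromatic ring stand at higher numbers than the cyclobutyl one. Nothing available explains these shifts.

Going by these compounds, the step from compound 2 to compound 3 removes the methyl and lengthens the tether together, so the share of each stays open; a plain phenyl in place of 3-methylphenyl would separate them. On these data alone, whether cyclopentyl or cyclohexyl at this place would match cyclobutyl also remains open.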